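The compounds below may be only part of what the source reports. "The series", "measured", "known", "first", "only" and "open" are said of these compounds alone.

Compound 3 `C=CCOC(=O)C1=C(C)NC(C)=C(C(=O)OC)C1c1cccc([N+](=O)[O-])c1` gives 15 nM in a functional assay on HEK293 cells for antagonist activity at Voltage-dependent L-type calcium channel subunit alpha-1D (Rattus norvegicus), read by FLIPR; a lower number here means a stronger inhibitor, a higher number a weaker inhibitor. Compound 1 `CCCCC1=C(C(=O)OCC)C(c2cccc([N+](=O)[O-])c2)C(C(=O)OCC)=C(C)N1` gives 20 nM, a number within the scatter of that for compound 3, while compound 2 `CCOC(=O)C1=C(C)NC(/C=C/c2ccc([N+](=O)[O-])cc2)=C(C(=O)OCC)C1c1cccc([N+](=O)[O-])c1` gives 2060 nM, far above both. Among the measured compounds shown here, the only measured step, a 100-fold higher number from compound 1 to compound 2 (2.01 log units; beyond the scatter), comes from a change on a double-bonded ring carbon and so says nothing directly about a change on a saturated chain carbon bound to an oxygen next to a carbonyl group. Compound 4 `COC(=O)C1=C(C)NC(C)=C(C(=O)OCc2ccc(F)c(F)c2)C1c1cccc([N+](=O)[O-])c1` differs from compound 3 by 3,4-difluorophenyl in place of vinyl on a saturated chain carbon bound to an oxygen next to a carbonyl group. For the measured compounds named here, with no measured step touching that place, no change beyond the scatter is expected, so compound 4 is estimated to give 15 nM, between 4 nM and 60 nM, an expected step of no change at the digits printed from compound 3 to compound 4 (within the scatter).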

Compound 4, half-maximal inhibitory concentration: 20 nM
Compound 4: the middle estimate sits 1.3-fold (0.12 log units) below what was measured, within the range that was stated.
By their numbers in this assay, from the lowest: compounds 3, 1 and 4 (each within the scatter of the next); then compound 2.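

In this assay, putting 3,4-difluorophenyl in place of vinyl on a saturated chain carbon bound to an oxygen next to a carbonyl group brings a 1.3-fold higher number from compound 3 to compound 4 (0.12 log units; within the scatter) and so no real change. At this place, then, a group of 8 heavy atoms with an aromatic ring stands in for one of 2 heavy atoms with no loss of inhibition. No supporting data explain this result. From the compounds shown here alone, whether plain benzyl, an amine or a carboxylic acid would fit here as well stays open.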